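The compounds below may be only part of what the source reports. "The series", "measured", "known", "first", "only" and "open" are said of these compounds alone.

Two compounds have readings in an ADME assay on LLC-PK1 cells (Sus scrofa) for permeability; on this read-out lower numbers stand for lower permeability and higher numbers for higher permeability. Compound 1 `CCn1c(-c2cnc(C)nc2)nc2c(N[C@H]3CCN(C(=O)N4CC(OC)C4)C3)ncnc21` gives 10 10^-6 cm/s in this assay. Compound 2 `CCn1c(-c2ccc(C(F)(F)F)nc2)nc2c(O[C@H]3CCN(C(=O)[C@H]4C[C@@H](OC)C4)C3)ncnc21` gives 35 10^-6 cm/s in this assay, the higher of the two numbers, and its gap to compound 1 lies beyond the usual scatter of repeated measurements. Compound 3 `CCn1c(-c2ccc(C(F)(F)F)nc2)nc2c(O[C@H]3CCN(C(=O)C4CCOC4)C3)ncnc21` has not yet been measured. It differs from compound 2 in one place: oxolan-3-yl in place of 3-methoxycyclobutyl on a carbonyl carbon. Within the data shown here, no measured pair shows this change, and the size of its step is unknown. Among the measured compounds shown here, with only two readings to go on, compound 3 is expected to stay close to compound 2, with a modest downward step a 1.3-fold lower number from compound 2 to compound 3 (0.10 log units; within the scatter) that need not exceed the scatter. Compound 3 is accordingly estimated at 28 10^-6 cm/s in this assay, with a plausible range from 14 10^-6 cm/s to 50 10^-6 cm/s.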

Compound 3, apparent permeability: 27 10^-6 cm/s
The estimate for compound 3 lay 1.0-fold (0.02 log units) above the measured number; measured number inside the range.
By their numbers in this assay, from the lowest: compound 1; then compounds 3 and 2 (each within the scatter of the next).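

In this assay, among these compounds, the first single-place change in this set, oxolan-3-yl in place of 3-methoxycyclobutyl on a carbonyl carbon, gives a 1.3-fold lower number from compound 2 to compound 3 (0.11 log units; within the scatter). At this position, on a carbonyl carbon whose other neighbour is an amide-type nitrogen in a ring, a four-membered non-aromatic ring of carbon only can therefore give way to a five-membered non-aromatic ring with one hetero atom without a step beyond the scatter, and both groups count the same hydrogen-bond donors and acceptors. Nothing measured here accounts for the size of this step.

On these data alone, whether a group of another kind on this carbonyl carbon, such as an amine or a carboxylic acid, would stay as close remains open. Compound 1 differs from compound 2 and compound 3 in more than one place, so its separate position in this assay cannot be traced to any single part.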